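The source may report more compounds than this note shows. Statements on the series, on what has been measured and on what is new or still open speak of the compounds shown alone.

Measured so far in an assay on HEK293 cells for inhibition of transient receptor potential cation channel subfamily M member 8 (Homo sapiens), read by FLIPR, with stated times of 5 min and 3 min; a higher number here means a weaker inhibitor, a lower number a stronger inhibitor:
Compound 1, `CCOC(=O)c1cnc(-c2ccccc2)s1`: the limit > 100000 nM.
Compound 2, `CCOC(=O)c1sc(-c2ccccc2)nc1OC`: the limit > 100000 nM.
Compound 3, `CCOC(=O)c1sc(-c2ccccc2)nc1N`: the limit > 100000 nM.

Compound 3 stands at a limit of this assay, not at a number, and so do the other two values shown (the limit of > 100000 nM in this assay, at which 3 of the 3 values shown sit). Compound 4, `CCOC(=O)c1sc(-c2ccccc2)nc1NC(=O)C(F)(F)F`, differs from compound 3 in one place: (trifluoromethyl)carbonyl in place of hydrogen on a nitrogen on an aromatic ring. The measured steps a step that the two limits leave unreadable from compound 1 to compound 3 and a step that the two limits leave unreadable from compound 2 to compound 3 both run between limits and give no readable size, so no bearing on this change can be drawn from them. With all three values at the limit, compound 4 is expected to stay near it, the step of an at least 1.6-fold lower number from compound 3 to compound 4 (0.22 log units; that floor lies within the scatter) being the estimate. Compound 4 is estimated at 60000 nM, between 5000 nM and 300000 nM.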

Compound 4, half-maximal inhibitory concentration: 7700 nM
Compound 4: middle estimate off by 7.8-fold (0.89 log units), on the high side, and the stated range covers the measured number.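

In this assay, (trifluoromethyl)carbonyl in place of hydrogen on a nitrogen on an aromatic ring gives a readable step at this position: an at least 12-fold lower number from compound 3 to compound 4 (1.11 log units; beyond the scatter). The same group, as ((trifluoromethyl)carbonyl)amino, also gives an at least 12-fold lower number from compound 2 to compound 4 (1.11 log units; beyond the scatter) and an at least 12-fold lower number from compound 1 to compound 4 (1.11 log units; beyond the scatter). The steps among compound 1, compound 2 and compound 3 cannot be read, and only compound 4 comes off the limit: the limit of > 100000 nM in this assay, at which 3 of the 4 values shown sit.

As far as these compounds go, it remains open whether an acetyl group on that nitrogen would give a similar step, which leaves the share of the trifluoromethyl unknown. Also open, from the compounds shown here alone, is how a carboxylic acid in place of the ethyl ester would read.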